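Working notes: step from compound 2 to compound 3

The compounds below may be only part of what the source reports. "The series", "measured", "known", "first", "only" and "open" are said of these compounds alone.

Measured so far:
compound 1 `COc1cc(-c2nn(-c3cccc(NC(=O)Nc4ccc(Cl)c(Cl)c4)c3)cc2-c2ccncc2)ccc1Cl` — 20300 nM
compound 2 `COc1cc(-c2nn(-c3cccc(NC(=O)Nc4cccc(C(F)(F)F)c4)c3)cc2-c2ccncc2)ccc1Cl` — 5430 nM

Among the measured compounds shown here, compound 2 holds the lowest of the two numbers in a functional assay on SF-268 cells (Homo sapiens) for inhibition, read by sulforhodamine B assay, with a stated time of 48 h; a higher number here means a weaker inhibitor of growth, a lower number a stronger inhibitor of growth; its only neighbour is compound 1, and the step of a 3.7-fold lower number from compound 1 to compound 2 (0.57 log units; beyond the scatter) lies beyond the scatter. Compound 3 `COc1cc(-c2nn(-c3cccc(NC(=O)c4ccc(Cl)c(C(F)(F)F)c4)c3)cc2-c2ccncc2)ccc1Cl` is not yet measured in this assay. It differs from compound 2 by 4-chloro-3-(trifluoromethyl)phenyl in place of (3-(trifluoromethyl)phenyl)amino on a carbonyl carbon. For the measured compounds named here, the one measured step, a 3.7-fold lower number from compound 1 to compound 2 (0.57 log units; beyond the scatter), concerns an exchange of one aryl ring for another on the amide-type nitrogen while that nitrogen stays in place; it does not touch the carbonyl carbon, so it bears on the present change only loosely. Going by the values given here, no measured pair shows what removing the amino linkage and setting the aryl directly on the carbonyl does in this assay. The expectation for compound 3 is therefore set close to compound 2, with a wide range to cover both directions, and the step of a 1.1-fold higher number from compound 2 to compound 3 (0.04 log units; within the scatter) is expected to stay within the scatter. Compound 3 is estimated at 6000 nM, with a range from 1500 nM to 24000 nM.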

Compound 3, concentration for total growth inhibition: > 32500 nM
Compound 3: a limit, no number; the forecaster's own chance of this, stated with the estimate: 10%; middle value at least 5.4-fold (0.73 log units) from the limit.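

In this assay, the change on the carbonyl carbon, with 4-chloro-3-(trifluoromethyl)phenyl in place of (3-(trifluoromethyl)phenyl)amino, gives an at least 5.9-fold higher number from compound 2 to compound 3 (0.77 log units; beyond the scatter), which runs opposite to the earlier aryl exchange on the amide-type nitrogen, a 3.7-fold lower number from compound 1 to compound 2 (0.57 log units; beyond the scatter). Compound 3 stands at a limit of the assay and has no number, so the size of both of its steps is known only as a floor: the limit of > 32500 nM in this assay, at which 1 of the 3 values shown sits. That floor separates compound 3 from compound 2, showing that this position does not tolerate the change as the amide-type nitrogen tolerated the aryl exchange, whereas an at least 1.6-fold higher number from compound 1 to compound 3 (0.20 log units; that floor lies within the scatter) does not separate compound 3 firmly from compound 1.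

The step from compound 2 combines loss of the amino nitrogen, with its hydrogen-bond donor, and gain of the chlorine, and the compounds shown cannot apportion the loss of growth inhibition between the two. From the compounds shown here alone, it also remains open whether a methylene link in place of the amino nitrogen, or the plain 3-(trifluoromethyl)phenyl ring set directly on the carbonyl, would read closer to compound 2.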